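Adding 1H-pyrazol-1-yl to compound 1

The compounds below may be only part of what the source reports. "The series", "measured", "known", "first", "only" and "open" are said of these compounds alone.

Of the compounds shown here, two have so far been measured in an ADME assay on microsomes from liver (Mus musculus, strain CD1) for metabolic stability, read by HPLC, using NADPH, with a stated time of 30 min; on this read-out higher numbers stand for fast clearance and lower numbers for slow clearance.

Compound 1 `COc1cccc(NC(=O)c2nnn(Cc3ccccc3)c2N)c1` gives 3.7 mL.min-1.g-1
Compound 2 `COc1cccc(NC(=O)c2nnn(Cc3cc(C)on3)c2N)c1` gives 2.6 mL.min-1.g-1

Among the compounds with values here, on these numbers compound 1 cannot be separated from compound 2, the only measured step being a 1.4-fold lower number from compound 1 to compound 2 (0.15 log units; within the scatter). Compound 3 `COc1cccc(NC(=O)c2nnn(Cc3ccc(-n4cccn4)cc3)c2N)c1` keeps the core of compound 1 and differs from it by 1H-pyrazol-1-yl in place of hydrogen on an aromatic carbon. In words, this is 1H-pyrazol-1-yl in place of hydrogen on an aromatic carbon. Within the data shown here, no measured compound carries a group in that place, so the data hold no direct measure of such an addition. The nearest guide is compound 2, where the whole phenyl is replaced, and that step, a 1.4-fold lower number from compound 1 to compound 2 (0.15 log units; within the scatter), bears on the change only indirectly. It offers no sign of a large effect in this assay, so a slight upward drift at most is expected, with nothing beyond the scatter. The estimated step is a 1.2-fold higher number from compound 1 to compound 3 (0.09 log units; within the scatter). For compound 3 the estimated value is 4.5 mL.min-1.g-1, with an expected range from 2.2 mL.min-1.g-1 to 9 mL.min-1.g-1.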

Compound 3, intrinsic clearance in microsomes: 2.3 mL.min-1.g-1
The estimate for compound 3 lay 2.0-fold (0.29 log units) above the measured number; the measured number falls inside the stated range.
By their numbers in this assay, from the lowest: compounds 3, 2 and 1 (each within the scatter of the next).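

In this assay the addition gives a 1.6-fold lower number from compound 1 to compound 3 (0.21 log units; within the scatter) and so cannot be told apart from compound 1. Within the data shown here, this is the first reading for any group on this aromatic carbon, para to a large group, as the earlier compounds carried only hydrogen there or replaced the whole phenyl. It shows that 1H-pyrazol-1-yl, with its 5 heavy atoms and one five-membered aromatic ring, can stand in this place without moving intrinsic clearance in microsomes beyond the scatter, although a single pair of compounds shows this for this group alone. Nothing in the data accounts for the reading, and no measurement offers a cause for it.

As far as these compounds go, whether a smaller or differently built group in the same place, such as an amine, a carboxylic acid or a longer chain, would also stay within the scatter of compound 1 remains open. From the compounds shown here alone, it is equally open whether 1H-pyrazol-1-yl would behave in the same way if placed on the 5-methyl-1,2-oxazol-3-yl ring of compound 2, or on another position of the phenyl ring of compound 1.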